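A few compounds are considered here, and "the series" means these few. Any claim that something is new, unique, unknown or untested is made for them only; others in the source may bear on it.

Measured so far in a functional assay on HeLa cells (Homo sapiens) for inhibition; a lower number here means a stronger inhibitor, a higher number a weaker inhibitor:
compound 1 `Oc1ccc(-c2cc(-c3ccc(F)cc3)cc(-c3ccccc3O)n2)cc1` gives > 50000 nM, a limit of the assay.
compound 2 `Oc1ccc(-c2cc(-c3ccc(F)cc3)cc(-c3cccc(O)c3)n2)cc1` gives 8080 nM.
compound 3 `Oc1ccc(-c2cc(-c3cccc(C(F)(F)F)c3)cc(-c3cccc(O)c3)n2)cc1` gives 16200 nM.

Compound 2 holds the lowest of the two numbers, with compound 3 close by: a 2.0-fold higher number from compound 2 to compound 3 (0.30 log units; within the scatter). Compound 1 sits at the limit of > 50000 nM in this assay, at which 1 of the 3 values shown sits. The change an at least 6.1-fold lower number from compound 1 to compound 2 (0.79 log units; beyond the scatter) came with 3-hydroxyphenyl in place of 2-hydroxyphenyl on an aromatic carbon.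

Compound 4 `Oc1ccc(-c2cc(-c3ccc(OC(F)(F)F)cc3)cc(-c3cccc(O)c3)n2)cc1` is not yet measured. It differs from compound 2 by trifluoromethoxy in place of fluoro on an aromatic carbon. Among the measured compounds shown here, the one measured step touching the same 4-fluorophenyl group, a 2.0-fold higher number from compound 2 to compound 3 (0.30 log units; within the scatter), stayed within the scatter, so a step within the scatter is expected here too: a 1.5-fold higher number from compound 2 to compound 4 (0.17 log units; within the scatter). Compound 4 is therefore estimated at 12000 nM, with a range from 5000 nM to 30000 nM.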

Compound 4, half-maximal inhibitory concentration: 27800 nM
The estimate for compound 4 lay 2.3-fold (0.36 log units) below the measured number, within the range that was stated.
By their numbers in this assay, from the lowest: compounds 2, 3 and 4 (each within the scatter of the next, the first and the last beyond it). At a limit, above all of these: compound 1.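

In this assay trifluoromethoxy in place of fluoro came with a 3.4-fold higher number from compound 2 to compound 4 (0.54 log units; beyond the scatter) and so the group at this place on the ring can move the number beyond the scatter. The earlier step of a 2.0-fold higher number from compound 2 to compound 3 (0.30 log units; within the scatter) on the same 4-fluorophenyl group had not shown that. Nothing measured here accounts for the rise in the number. Going by these compounds, whether a methoxy, an amine or a carboxylic acid at this place would give a lower number than fluoro stays open.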